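A few compounds are considered here, and "the series" means these few. Any claim that something is new, unique, unknown or untested is made for them only; others in the source may bear on it.

Measured compounds and their values:
- compound 1, `Cc1ccc(S(=O)(=O)NC(=O)/C=C/c2ccccc2)cc1`, 13.8 ug/mL
- compound 2, `O=C(/C=C/c1ccccc1)NS(=O)(=O)c1ccc(F)cc1`, 2.1 ug/mL
- compound 3, `Cc1ccc(S(=O)(=O)NC(=O)/C=C/c2ccc(N(C)C)cc2)cc1`, 4.3 ug/mL

All three were tested in a functional assay on B16-F10 cells (Mus musculus) for antiproliferative activity, read by ELISA and MTT assay, with a stated time of 48 h; a lower number here means a stronger inhibitor, a higher number a weaker inhibitor. Compound 2 is made from compound 1 by one change, (fluoro in place of methyl on an aromatic carbon), and that step gave a 6.6-fold lower number from compound 1 to compound 2 (0.82 log units; beyond the scatter). Compound 3 is made from compound 1 by a different change, (dimethylamino in place of hydrogen on an aromatic carbon), which gave a 3.2-fold lower number from compound 1 to compound 3 (0.51 log units; beyond the scatter). Compound 2 and compound 3 differ from each other by both changes at once, and their two values in this assay show compound 2 with the lower number.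

Compound 4, `CN(C)c1ccc(/C=C/C(=O)NS(=O)(=O)c2ccc(F)cc2)cc1`, has not yet been measured. It differs from compound 3 by fluoro in place of methyl on an aromatic carbon, which is the same change that leads from compound 1 to compound 2, made on a core that carries the dimethylamino group seen in compound 3. The place of the change is described in the same words in both cases.

Because compound 2 gave a 6.6-fold lower number from compound 1 to compound 2 (0.82 log units; beyond the scatter) when this change was made on the core of compound 1, a step in the same direction is expected from compound 3 to compound 4, though repeating a change on a second core does not always give the same size of step. The expected step is a 4.8-fold lower number from compound 3 to compound 4 (0.68 log units; beyond the scatter). Compound 4 is therefore estimated at 0.9 ug/mL in this assay, with a plausible range from 0.3 ug/mL to 3 ug/mL.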

Compound 4, half-maximal inhibitory concentration: 2.3 ug/mL
Compound 4: middle estimate off by 2.6-fold (0.41 log units), on the low side, and the stated range covers the measured number.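

In this assay, putting fluoro in place of methyl on the core that carries the dimethylamino group gave a 1.9-fold lower number from compound 3 to compound 4 (0.27 log units; within the scatter), so this change did not carry over at the size it had on the core of compound 1: the same change on two cores in this assay, a 6.6-fold lower number (0.82 log units; beyond the scatter) from compound 1 to compound 2 and a 1.9-fold lower number (0.27 log units; within the scatter) from compound 3 to compound 4, 3.5-fold (0.55 log units) apart, beyond the scatter of two such steps Seen from the other side, putting dimethylamino in place of hydrogen on the core that carries fluoro gave a 1.1-fold higher number from compound 2 to compound 4 (0.04 log units; within the scatter), and this step also differs from its counterpart on the core with methyl: the same change on two cores in this assay, a 3.2-fold lower number (0.51 log units; beyond the scatter) from compound 1 to compound 3 and a 1.1-fold higher number (0.04 log units; within the scatter) from compound 2 to compound 4, 3.5-fold (0.55 log units) apart, beyond the scatter of two such steps Across these four compounds, then, the two changes do not simply add up, since the size of each step depends on the group already present at the other end of the molecule, but the numbers do not show why this happens, and two cores in a single assay give no rule for predicting the step on a third core.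

As far as these compounds go, it remains open whether a chloro or methoxy group in the place of the fluoro would behave in the same way when the dimethylamino group is present. From the compounds shown here alone, it is equally open whether a smaller amine, such as methylamino, or a carboxylic acid in the place of the dimethylamino group would leave the effect of the fluoro change as small as it is on compound 3.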